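Swapping the ketone's phenyl for thiophene

The compounds below may be only part of what the source reports. "The series", "measured", "known", "first", "only" and "open" are said of these compounds alone.

Compound 1 `Cn1cc(/C=C/C(=O)c2ccccc2)cc1/C=C/C(=O)NO` is the reference point here. In an assay on isolated protein for inhibition of histone deacetylase HD1B (Zea mays) (a lower number here means a stronger inhibitor, a higher number a weaker inhibitor), compound 1 gives 260 nM. Among the measured compounds shown here, compound 2 `Cn1cc(/C=C/C(=O)c2cccc(Br)c2)cc1/C=C/C(=O)NO` is the only other measured compound, and in this assay compound 2 gives 480 nM; the step of a 1.8-fold higher number from compound 1 to compound 2 (0.27 log units; within the scatter) means the two numbers are not distinguishable, so compound 1 stands alongside compound 2 rather than apart from it. Compound 3 `Cn1cc(/C=C/C(=O)c2ccsc2)cc1/C=C/C(=O)NO` changes the reference at a different place: thiophen-3-yl in place of phenyl on a carbonyl carbon. For the measured compounds named here, no measured step touches this part of the molecule; the one step available, from compound 1 to compound 2, alters a substituent on the phenyl rather than the ring itself, and it stayed within the scatter. The expectation for this assay is therefore a step of a 1.3-fold higher number from compound 1 to compound 3 (0.13 log units; within the scatter), with no direction beyond the scatter. Compound 3 is estimated at 350 nM, in a range from 150 nM to 900 nM.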

Compound 3, half-maximal inhibitory concentration: 22600 nM
Compound 3: the middle estimate sits 65-fold (1.81 log units) below what was measured; the whole stated range lies below it.
By their numbers in this assay, from the lowest: compounds 1 and 2 (each within the scatter of the next); then compound 3.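

In this assay the ring on the carbonyl carbon turns out to matter far more than the earlier pair suggested: thiophen-3-yl in place of phenyl gives an 87-fold higher number from compound 1 to compound 3 (1.94 log units; beyond the scatter) while the bromo step on the phenyl ring stayed within the scatter. Set against the brominated ring, the same thiophen-3-yl gives a 47-fold higher number from compound 2 to compound 3 (1.67 log units; beyond the scatter) so the six-membered carbon rings of both earlier compounds stand well apart from this five-membered sulfur ring. Nothing available gives a reason for this large loss.

The compounds shown do not tell whether the loss follows the sulfur atom or the smaller ring. A furan-3-yl ring, with oxygen in place of sulfur, or a pyridin-3-yl ring, six-membered with a nitrogen, would help separate those two readings.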